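Swapping the Chlorophenyl Arm for a Methylphenyl Arm

This account rests on a few compounds, and the source may have more. Where it says the series, first, only, none or still open, it means among the compounds named here.

Measured so far:
compound 1, `COc1ccccc1/C=c1/[nH]c(=O)/c(=C\c2ccccc2OC)n(C)c1=O`: "not active" (no number reported)
compound 2, `C=CCn1c(=O)/c(=C\c2ccccc2Cl)[nH]c(=O)/c1=C\c1ccccc1OC`: 5100 nM
compound 3, `COc1ccccc1/C=c1/[nH]c(=O)/c(=C\c2ccccc2OC)[nH]c1=O`: "not active" (no number reported)

Of the compounds shown here, three built on the same shared core have been tested in a functional assay on HeLa cells (Homo sapiens) for cytotoxicity, read by CCK-8 assay, with a stated time of 72 h; a lower number here means a stronger inhibitor, a higher number a weaker inhibitor. Only compound 2 has a number to show: in this assay compound 2 gives 5100 nM. Compound 1 and compound 3, each carrying two 2-methoxyphenyl arms, returned no number at all, so compound 2 stands alone as the single quantified entry, with nothing to compare it against step by step.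

Compound 4, `C=CCn1c(=O)/c(=C\c2cccc(C)c2)[nH]c(=O)/c1=C\c1ccccc1OC`, has not yet been measured. It differs from compound 2 in one place:

3-methylphenyl in place of 2-chlorophenyl on a double-bonded chain carbon bound to an aromatic carbon

Going by the values given here, no step between two measured compounds can guide this change, so the expectation rests on compound 2 alone. Both arms entering and leaving are single six-membered carbon rings of equal size, with no donors or acceptors on either side. With the 3-methylphenyl group moved into the place of the 2-chlorophenyl group, the step from compound 2 to compound 4 is expected to be small, most likely within the scatter, with a slight lean toward weaker inhibition because compound 2 gives 5100 nM and the two entries without a number both lack a chlorophenyl arm; the estimated step is a 1.6-fold higher number from compound 2 to compound 4 (0.20 log units; within the scatter). Compound 4 is expected to give about 8000 nM in this assay, within a range from 2500 nM to 25000 nM.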

Compound 4, half-maximal inhibitory concentration: 19300 nM
Compound 4: middle estimate off by 2.4-fold (0.38 log units), on the low side; the measured number falls inside the stated range.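

In this assay, the arm on the double-bonded chain carbon bound to an aromatic carbon proves to matter, with a 3.8-fold higher number from compound 2 to compound 4 (0.58 log units; beyond the scatter) when 3-methylphenyl replaces 2-chlorophenyl, a modest but genuine loss of strength. Going by these compounds alone, this is the first measured step on the shared core, and it shows that two arms with the same number of heavy atoms, each a single six-membered aromatic ring of carbon only with no hydrogen-bond donors or acceptors, can still give clearly different results, although compound 4 does retain a measurable number. Nothing measured here explains the difference between these two arms.

This single step swaps chlorine for methyl and also changes the number in the group's name, so the two changes remain tangled until a methylphenyl arm numbered like 2-chlorophenyl, or a chlorophenyl arm numbered like 3-methylphenyl, can be compared. The compounds shown also leave open how this position would respond to a plain phenyl ring or to an arm carrying an amine or a carboxylic acid.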